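Trifluoromethyl for nitro on the benzyl arm

This account rests on a few compounds, and the source may have more. Where it says the series, first, only, none or still open, it means among the compounds named here.

Two compounds of a shared core were examined in a functional assay on Cortical neurone cells (Rattus norvegicus, strain Sprague-Dawley), read by MTT assay, with stated times of 24 h and 2 h, tested at 0.1 uM; a lower number here means a weaker effect, a higher number a stronger effect of the compound at the concentration tested. Compound 1 `COC(=O)C1=CN(C)C(=O)[C@@H]2C(CN3CCN(Cc4ccc(C(F)(F)F)cc4)CC3)=CC[C@H]12` gives 63%. Compound 2 `COC(=O)C1=CN(C(C)C)C(=O)[C@@H]2C(CN3CCN(Cc4ccc([N+](=O)[O-])cc4)CC3)=CC[C@H]12` gives 67.1%, the highest of the two numbers, yet its nearest neighbour is compound 1, whose number lies within the scatter of compound 2, so the two cannot be ordered. Compound 3 `COC(=O)C1=CN(C(C)C)C(=O)[C@@H]2C(CN3CCN(Cc4ccc(C(F)(F)F)cc4)CC3)=CC[C@H]12` has not been measured. It differs from compound 2 in one place: trifluoromethyl in place of nitro on an aromatic carbon. Among the compounds with values here, no step between measured compounds is recorded for this change, so its size must be guessed. The account expects no step beyond the scatter, with a slight lean downward because compound 1 gives 63%. The estimated step is a number 3.1 percentage points lower from compound 2 to compound 3 (within the scatter). Compound 3 is therefore expected to give about 64%, within a range from 52% to 76%.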

Compound 3, a percentage reported as activity, at one concentration (the size of the read-out at that concentration, not a potency): 59.1%
Estimate against measurement, compound 3: 4.9 percentage points above; measured number inside the range.
By their numbers in this assay, from the lowest: compounds 3, 1 and 2 (each within the scatter of the next).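

Compound 3 turns a comparison that differed in two places into two single changes. In this assay, trifluoromethyl in place of nitro on the aromatic carbon gives a number 8 percentage points lower from compound 2 to compound 3 (within the scatter), while isopropyl in place of methyl on the amide-type nitrogen in a ring gives a number 3.9 percentage points lower from compound 1 to compound 3 (within the scatter), so neither change separates its pair of compounds. Nothing available bears on why these compounds read as they do.

As far as these compounds go, whether an amine or a carboxylic acid on that aromatic carbon, or a longer chain on the ring nitrogen, would give a step beyond the scatter remains open. These readings come from one concentration, so they show the size of the effect of all three compounds at that concentration only.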